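The source may report more compounds than this note shows. Statements on the series, on what has been measured and on what is new or still open speak of the compounds shown alone.

Compound 1 `C=C1C(=O)OC[C@H]1CCOC(=O)Nc1ccccc1`: 390 nM
Compound 2 `C=C1C(=O)OC[C@@H]1CCOC(=O)Nc1ccc(I)cc1`: 790 nM
Compound 3 `C=C1C(=O)OC[C@H]1CCOC(=O)Nc1ccc(I)cc1`: 490 nM

In a functional assay on RAW264.7 cells (Mus musculus) for inhibition, with a stated time of 30 min (a lower number here means a stronger inhibitor, a higher number a weaker inhibitor), compound 2 stands highest of the three numbers shown. Its nearest neighbour is compound 3, reached by a 1.6-fold lower number from compound 2 to compound 3 (0.21 log units; within the scatter), a step that rests on the fact that compounds 2 and 3 differ only in the configuration as drawn alone; its furthest is compound 1, whose number lies beyond the scatter from that of compound 2. Compound 4 `C=C1C(=O)OC[C@@H]1CCOC(=O)Nc1ccc(CC)cc1` differs from compound 2 by a single change: ethyl in place of iodo on an aromatic carbon. Among the compounds with values here, the one measured step that touches this same aromatic carbon is a 1.3-fold higher number from compound 1 to compound 3 (0.10 log units; within the scatter), and it stayed within the scatter. A further exchange at that carbon is therefore not expected to carry the number beyond the scatter in either direction. For compound 4 the estimate is 700 nM, with a range from 350 nM to 1400 nM, which amounts to an expected step of a 1.1-fold lower number from compound 2 to compound 4 (0.05 log units; within the scatter).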

Compound 4, half-maximal inhibitory concentration: 1260 nM
For compound 4 the middle estimate is 1.8-fold (0.26 log units) below the measured one; measured number inside the range.
By their numbers in this assay, from the lowest: compounds 1, 3, 2 and 4 (each within the scatter of the next, the first and the last beyond it).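

In this assay, ethyl in place of iodo on the aromatic carbon gives a 1.6-fold higher number from compound 2 to compound 4 (0.20 log units; within the scatter). This is the first step at that carbon shown for the configuration drawn in compound 2, and it exchanges one substituent for another rather than for hydrogen; like the earlier step at that carbon, it stays within the scatter. Nothing in the data shown gives a cause for this step.

Going by these compounds, whether an amine, a carboxylic acid or a longer chain at this carbon would also stay within the scatter remains open. So does the number for ethyl in the opposite configuration.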